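Trimming the Acid Chain of Compound 3

The compounds below may be only part of what the source reports. "The series", "measured", "known", "first", "only" and "open" are said of these compounds alone.

Of the compounds shown here, three have been measured in a functional assay for inhibition, with Homo sapiens as the target; a higher number here means a weaker inhibitor, a lower number a stronger inhibitor. Compound 1, `Cc1ccc(S(=O)(=O)N[C@@H](CCC(=O)N2CCC3(CC2)CCN(c2ccncc2)CC3)C(=O)O)cc1`, gives 78 nM. Within the data shown here, compound 2, `CCCCS(=O)(=O)N[C@@H](CCC(=O)N1CCC2(CC1)CCN(c1ccncc1)CC2)C(=O)O`, gives 768 nM, and the one measured step, a 9.8-fold higher number from compound 1 to compound 2 (0.99 log units; beyond the scatter), lies on a sulfonyl substituent. Compound 3, `N=C(N)c1ccc(C(=O)N2CCC3(CCN(C(=O)CCCC(=O)O)CC3)CC2)cc1`, gives 10300 nM, the highest of the three numbers: it stands beyond the scatter from both compound 2 and compound 1, so it is the weakest inhibitor of the set.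

Compound 4, `N=C(N)c1ccc(C(=O)N2CCC3(CCN(C(=O)CC(=O)O)CC3)CC2)cc1`, differs from compound 3 in one place: carboxy in place of 2-carboxyethyl on a saturated chain carbon bound to a carbonyl carbon. Among the measured compounds shown here, no measured step bears on this change; compound 3 shares neither the sulfonyl group of compound 1 and compound 2 nor the rest of their arrangement, and the only step, a 9.8-fold higher number from compound 1 to compound 2 (0.99 log units; beyond the scatter), concerns a different part of the molecule. With no guidance from the measured pairs, and with compound 3 already weak at 10300 nM, the expectation is at most a small shift in either direction, leaning toward a weaker inhibitor. Compound 4 is therefore estimated to give 20000 nM, with a range from 5000 nM to 80000 nM. The step this implies, a 1.9-fold higher number from compound 3 to compound 4 (0.29 log units; within the scatter), is expected to be a modest weakening, with a fair chance that the assay reports only a limit.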

Compound 4, half-maximal inhibitory concentration: 9300 nM
Compound 4: the middle estimate sits 2.2-fold (0.33 log units) above what was measured; measured number inside the range.
By their numbers in this assay, from the lowest: compound 1; then compound 2; then compounds 4 and 3 (each within the scatter of the next).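

In this assay, the swap of 2-carboxyethyl (5 heavy atoms) for carboxy (3 heavy atoms) on a saturated chain carbon bound to a carbonyl carbon gives a step that stays inside the scatter (a 1.1-fold lower number from compound 3 to compound 4 (0.04 log units; within the scatter)), so this read-out does not separate the two chain lengths at this position. Among these compounds, the earlier compounds offered only one step, on a sulfonyl substituent and beyond the scatter (a 9.8-fold higher number from compound 1 to compound 2 (0.99 log units; beyond the scatter)), whereas this pair gives the first reading on the acid chain and shows that, between these two groups, its length leaves the number unresolved. No measurement at hand bears on why these two chains read alike.

The compounds shown leave open whether a longer chain, or an ester or a primary amide in place of the carboxylic acid, would read any differently from compound 3 and compound 4. They also leave open whether the same shortening would read alike on the core of compound 1, where the acid sits on a chain that also carries a sulfonamide.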